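The source may report more compounds than this note shows. Statements on the series, on what has been measured and on what is new or still open speak of the compounds shown alone.

Notes on the series, tail flick.

Compound 1 `O=C(O)[C@@H]1CCCN1C(=O)CN(c1nc(Cl)nc2[nH]cnc12)C1CC1` is the reference point of the two measured compounds. In a functional assay on the whole organism (Tail, strain ICR) with Mus musculus as the target, in the tail flick test, with a stated time of 30 min, at a dose of 25 umol/kg by the oral route (a lower number here means a weaker effect, a higher number a stronger effect of the compound at the dose given), compound 1 gives 31.5%, the higher of the two numbers recorded. Compound 2 `CC(C)(C)OC(=O)NCCCC[C@H](NC(=O)CN(c1ncnc2c1ncn2C1CCCCO1)C1CC1)C(=O)OCc1ccccc1` shares part of the glycine-linked core but carries a different substitution pattern at several places; in this assay compound 2 gives 18.3%, which sits clearly lower than compound 1, beyond the usual scatter of the test. Going by the values given here, no single-point step between the two measured compounds is available, so the pair only shows that the two numbers differ.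

Compound 3 `C[C@H](NC(=O)CN(c1nc(Cl)nc2[nH]cnc12)C1CC1)C(=O)O` has not been measured. It differs from compound 1 at one place: (1-carboxyethyl)amino in place of 2-carboxypyrrolidin-1-yl on a carbonyl carbon. The change is (1-carboxyethyl)amino in place of 2-carboxypyrrolidin-1-yl on a carbonyl carbon, the carboxylic acid being kept while the ring is opened. With nothing in the series to anchor this kind of change, only a small downward step is expected, of the order of a number 6.5 percentage points lower from compound 1 to compound 3 (within the scatter), possibly not beyond the scatter. For compound 3 the expected read-out in this assay is therefore 25%, with a likely range from 8% to 42%.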

Compound 3, a percentage reported as activity, at one dose (the size of the read-out at that dose, not a potency): 48.1%
Compound 3: middle estimate off by 23.1 percentage points, on the low side; measured number outside the range, above it.
By their numbers in this assay, from the lowest: compound 2; then compound 1; then compound 3.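

Going by these compounds alone, replacing 2-carboxypyrrolidin-1-yl with (1-carboxyethyl)amino on a carbonyl carbon gives, in this assay, a number 16.6 percentage points higher from compound 1 to compound 3 (beyond the scatter) and provides the first single-place step. Within the data shown here, the carboxylic acid and its defined stereocentre remain in both compounds, so this pair shows that the five-membered ring can be opened without a loss in the read-out at this dose; the earlier pair differed at several places and could show only two separate numbers. The entering group also has no ring, fewer heavy atoms and one more hydrogen-bond donor, but no available measurement bears on why the read-out rises.

One step at one dose and one time point cannot show whether the rise would hold with the rest of the core changed, or how much of it would remain with a longer chain, such as 1-carboxypropylamino, at this place. Because compound 1 and compound 3 both carry the carboxylic acid, the pair also leaves open how the read-out would respond to a primary amide or an ester in its place.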